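The source may hold more compounds than are shown below. What is called first, only, known or untested is meant among the compounds shown, and "the series" means these compounds.

Compound 1 `O=C(c1ccc(OC(F)(F)F)cc1)N1CCC(N(C2CC2)S(=O)(=O)c2cccc(C(F)(F)F)c2)CC1`, compound 2 `CS(=O)(=O)c1ccccc1C(=O)N1CCC(N(C2CC2)S(=O)(=O)c2cccc(C(F)(F)F)c2)CC1`, compound 3 `NC(=O)c1cccc(C(=O)N2CCC(N(C3CC3)S(=O)(=O)c3cccc(C(F)(F)F)c3)CC2)c1` and compound 4 `CN(C)c1cccc(C(=O)N2CCC(N(C3CC3)S(=O)(=O)c3cccc(C(F)(F)F)c3)CC2)c1` share one core and differ only in the group attached to the carbonyl carbon. In an assay on cells for inhibition of Voltage-dependent L-type calcium channel subunit alpha-1C (Homo sapiens), read by FLIPR and calcium flux, tested at 3 uM (a lower number here means a weaker effect, a higher number a stronger effect of the compound at the concentration tested), compound 1 gives 88%, while compound 2 gives 39%. For the measured compounds named here, the single measured comparison, a number 49 percentage points lower from compound 1 to compound 2 (beyond the scatter), shows that exchanging this group can move the read-out a long way. In this assay compound 3 gives "not determined" (no result reported), so it stands without a number. The change from compound 3 to compound 4 is dimethylamino in place of carbamoyl on an aromatic carbon. Going by the values given here, no measured step repeats this change; the comparison of compound 1 with compound 2 involves other groups and only shows how wide the swing can be, so no direction can be favoured. Compound 4 is therefore expected near 55%, within a range from 20% to 90%.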

Compound 4, a percentage reported as inhibition, at one concentration (the size of the read-out at that concentration, not a potency): 63%
Compound 4: the middle estimate sits 8 percentage points below what was measured; low and high end bracket the measured number.
By their numbers in this assay, from the lowest: compound 2; then compound 4; then compound 1.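

With 3-(dimethylamino)phenyl on the carbonyl carbon, the read-out in this assay lands between the two earlier values: a number 24 percentage points higher from compound 2 to compound 4 (beyond the scatter), and a number 25 percentage points lower from compound 1 to compound 4 (beyond the scatter). Exchanging this group therefore gives three separate levels among these compounds, not just a high and a low one. The change from carbamoyl to dimethylamino itself cannot be read, as compound 3 has no number. Nothing available explains these differences. Also open, from the compounds shown here alone, is where a primary amine or a carboxylic acid on this aromatic carbon would fall.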